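Thioether side chain trimmed: expectation for compound 3

The source may hold more compounds than are shown below. What is called first, only, known or untested is meant among the compounds shown, and "the series" means these compounds.

Compound 1 `CSc1nncc2c(C)nc(C(C)C)n12` and compound 2 `CCOC(=O)CSc1nncc2c(C)ncn12` have both been run in a functional assay for inhibition, with Homo sapiens as the target; a lower number here means a stronger inhibitor, a higher number a weaker inhibitor. For compound 1 only a limit of the assay is recorded, > 48000 nM. For compound 2 likewise only a limit is recorded, > 48000 nM. Compound 2 therefore stands at the limit of > 48000 nM in this assay, at which 2 of the 2 values shown sit. Among the compounds with values here, no step between measured compounds is available; compound 1 and compound 2 differ in more than one place, so their two values show only that neither reached a measurable number. Compound 3 `CSc1nncc2c(C)ncn12` is the next compound to go into this assay. It differs from compound 2 by hydrogen in place of ethoxycarbonyl on a saturated chain carbon bound to a sulfur. Within the data shown here, with both measured values sitting at the limit, no measured step indicates which direction this change takes; the expectation is no step beyond the scatter in this assay, with a high chance that the result is again reported as a limit. Compound 3 is expected to give 60000 nM in this assay, within 20000 nM to 200000 nM. The expected, not measured, step is a step that the limit leaves unreadable from compound 2 to compound 3.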

Compound 3, half-maximal inhibitory concentration: > 48000 nM
Compound 3 was reported as a limit (the forecaster's own chance of this, stated with the estimate: 85%); the middle value is on the limit's open side.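

No step can be read from compound 2 to compound 3 or from compound 1 to compound 3, since all three results in this assay are limits of the assay: the limit of > 48000 nM in this assay, at which 3 of the 3 values shown sit. The compounds shown leave open whether any compound on this core gives a measurable value, and which of the changes, ethoxycarbonyl to hydrogen or isopropyl to hydrogen, moves it in which direction.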